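From Fluoro to Methoxy: Estimating Compound 4

A few compounds are considered here, and "the series" means these few. Any claim that something is new, unique, unknown or untested is made for them only; others in the source may bear on it.

Of the compounds shown here, three have been tested in a functional assay on MDA-MB-231 cells (Homo sapiens) for cytotoxicity, with a stated time of 48 h; on this read-out lower numbers stand for stronger inhibition and higher numbers for weaker inhibition. Compound 1 `O=[N+]([O-])c1ccc(CN2CCC(n3cc(CC(OCc4cc(-c5ccc(Br)cc5)no4)c4ccc(Br)cc4)nn3)CC2)cc1` reaches only a limit of the assay, > 25000 nM. Compound 2 `O=[N+]([O-])c1ccc(CN2CCC(n3cc(CC(OCc4cc(-c5ccccc5Br)no4)c4ccc(Br)cc4)nn3)CC2)cc1` likewise gives only a limit, > 25000 nM. Going by the values given here, compound 3 `O=[N+]([O-])c1ccc(CN2CCC(n3cc(CC(OCc4cc(-c5ccccc5F)no4)c4ccc(Br)cc4)nn3)CC2)cc1` is the single compound with a real number, 4000 nM, so it stands alone as the measured point, while the other two values sit at the limit of > 25000 nM in this assay, at which 2 of the 3 values shown sit.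

Compound 4 `COc1ccccc1-c1cc(COC(Cc2cn(C3CCN(Cc4ccc([N+](=O)[O-])cc4)CC3)nn2)c2ccc(Br)cc2)on1` differs from compound 3 in one place: methoxy in place of fluoro on an aromatic carbon. Among the compounds with values here, no measured step exchanges fluoro for methoxy, so the guidance is indirect. The nearest comparison is an at least 6.2-fold lower number from compound 2 to compound 3 (0.79 log units; beyond the scatter), together with an at least 6.2-fold lower number from compound 1 to compound 3 (0.79 log units; beyond the scatter); both show that the group at this position can shift the read-out strongly, but neither shows which way methoxy would move it. With that uncertainty, compound 4 is expected to be somewhat weaker than compound 3, at an estimated 8000 nM, with a range from 2000 nM to 25000 nM. That estimate corresponds to an expected step of a 2.0-fold higher number from compound 3 to compound 4 (0.30 log units; within the scatter) in this assay.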

Compound 4, half-maximal inhibitory concentration: > 25000 nM
Compound 4: no number, only a limit; the forecaster's own chance of this, stated with the estimate: 30%; at least 3.1-fold (0.49 log units) between middle value and limit.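

In this assay, methoxy in place of fluoro on this aromatic carbon gives an at least 6.2-fold higher number from compound 3 to compound 4 (0.79 log units; beyond the scatter), so a change here that does not swap one halogen for another also loses the measurable value. Among the groups shown at this place, only fluoro in compound 3 gives a number, while bromo in compound 2 and methoxy in compound 4 both end at a limit of the assay. The steps from compound 1 and from compound 2 to compound 4 cannot be read because both ends of each step are limits: the limit of > 25000 nM in this assay, at which 3 of the 4 values shown sit.

On these data alone, the true size of the step to compound 4 stays open, as compound 4 has only a limit. Also open, as far as these compounds go, is whether chloro, methyl or hydroxyl at this place would give a number, as fluoro does.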